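Hydroxypiperidine replacing piperidine on the chain of compound 3

This account rests on a few compounds, and the source may have more. Where it says the series, first, only, none or still open, it means among the compounds named here.

Three compounds share one core. Compound 1 `CC1(C)OCC(Cn2cc(Cn3c4c(c5ccccc53)C(=O)c3c[n+]([O-])c5ccccc5c3C4=O)nn2)O1` gives 230 nM in a functional assay on SH-SY5Y cells (Homo sapiens) for cytotoxicity, read by MTT assay, with a stated time of 72 h (a higher number here means a weaker inhibitor, a lower number a stronger inhibitor), compound 2 `O=C1c2c[n+]([O-])c3ccccc3c2C(=O)c2c1c1ccccc1n2Cc1cn([C@@H]2C[C@H](O)[C@@H](CO)O2)nn1` gives 150 nM, and compound 3 `O=C1c2c[n+]([O-])c3ccccc3c2C(=O)c2c1c1ccccc1n2CCCCN1CCCCC1` gives 230 nM. Compound 3 thus stands level with compound 1 at the digits shown, the two together highest of the three; compound 2 sits a 1.5-fold lower number from compound 1 to compound 2 (0.19 log units; within the scatter), within the scatter. Compound 4 `O=C1c2c[n+]([O-])c3ccccc3c2C(=O)c2c1c1ccccc1n2CCCN1CCC(O)CC1` differs from compound 3 by 4-hydroxypiperidin-1-yl in place of (piperidin-1-yl)methyl on a saturated chain carbon, three bonds along the chain from an aromatic nitrogen. Within the data shown here, no measured step touches this part of the molecule; the single step known, on the aromatic nitrogen, stayed within the scatter. Compound 4 is therefore expected to give 230 nM, in the range 100 nM to 520 nM, that is no change at the digits printed from compound 3 to compound 4 (within the scatter), no change beyond the scatter.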

Compound 4, half-maximal inhibitory concentration: 130 nM
Beside the measured number, compound 4's estimate is 1.8-fold (0.25 log units) above it; the range from low to high includes it.
By their numbers in this assay, from the lowest: compounds 4, 2, 1 and 3 (each within the scatter of the next).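

In this assay, the saturated chain now has a measured change of its own, with a 1.8-fold lower number from compound 3 to compound 4 (0.25 log units; within the scatter), so this exchange on the chain leaves the number within the scatter. Read one bond further out, 4-(piperidin-1-yl)butyl becomes 3-(4-hydroxypiperidin-1-yl)propyl, so the step alters the chain and adds a hydroxyl group together. Nothing available explains the result.

The compounds shown leave the two parts of this step unseparated, since neither 3-(piperidin-1-yl)propyl nor 4-(4-hydroxypiperidin-1-yl)butyl appears among them. They also leave open how a morpholine ring or a carboxylic acid on the piperidine would read here.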